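A few compounds are considered here, and "the series" means these few. Any claim that something is new, unique, unknown or untested is made for them only; others in the source may bear on it.

Measured compounds in an assay on HEK293 cells for positive allosteric modulation of metabotropic glutamate receptor 5 (Homo sapiens), read by FLIPR; on this read-out higher numbers stand for an effect only at larger amounts of compound and lower numbers for an effect already at smaller amounts:
- compound 2, `O=C(N1CCCCC1)N1CC(c2nc(-c3cccc(Cl)c3)no2)C1`: 370 nM
- compound 1, `O=C(C1CCCCC1)N1CC(c2nc(-c3cccc(F)c3)no2)C1`: 1000 nM
- compound 3, `Cc1ccc(S(=O)(=O)N2CC(c3nc(-c4cccc(Cl)c4)no3)C2)cc1`: a limit of the assay, > 10000 nM

Compound 2 gives the lowest of the two numbers shown in this assay; compound 1 stands at a higher number, and the gap is beyond the scatter. The third entry is not a number but a limit: the limit of > 10000 nM in this assay, at which 1 of the 3 values shown sits.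

The next compound in the series is compound 4, `O=C(C1CCC2(CCC2)CC1)N1CC(c2nc(-c3cccc(Cl)c3)no2)C1`, not yet measured in this assay. It differs from compound 2 at the carbonyl carbon:
a group of 9 heavy atoms (9 carbon; one four-membered non-aromatic ring of carbon only, one six-membered non-aromatic ring of carbon only) in place of a group of 6 heavy atoms (5 carbon, 1 nitrogen; one six-membered non-aromatic ring with 1 hetero atom), on a carbonyl carbon

Among the measured compounds shown here, no step between measured compounds covers this change, so the size of the step can only be expected, not read off. The bicyclic carbocycle entering in place of the piperidin-1-yl is a larger group, and the nearest comparison, compound 1 with a single six-membered carbocycle on the carbonyl and a different halogen, sits at a higher number than compound 2. A modest shift toward a higher number, within or only slightly beyond the scatter, is expected for compound 4. For compound 4 the estimate is 600 nM, with a range from 150 nM to 2500 nM. This estimate means a step of a 1.6-fold higher number from compound 2 to compound 4 (0.21 log units; within the scatter).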

Compound 4, half-maximal effective concentration: 1100 nM
Compound 4: the middle estimate sits 1.8-fold (0.26 log units) below what was measured; the range from low to high includes it.
By their numbers in this assay, from the lowest: compound 2; then compounds 1 and 4 (each within the scatter of the next). At a limit, above all of these: compound 3.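

On this assay, replacing piperidin-1-yl on the carbonyl carbon with the all-carbon group of 9 heavy atoms gives a 3.0-fold higher number from compound 2 to compound 4 (0.47 log units; beyond the scatter), the first step read at this position, and it shows that the position responds to this change. The nitrogen of piperidin-1-yl is not required for a measurable effect, since compound 4, with only carbon in this group, still gives a number and not a limit. No measurement shown bears on why the step has this size.

The step changes ring size and the atom bound to the carbonyl together, so their shares cannot be separated. Cyclohexyl on the carbonyl with the chlorine of compound 2 kept, or morpholin-4-yl in place of piperidin-1-yl, would separate them, and both remain open.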